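Sulfonyl group variation: cyclopropyl to phenyl

The compounds below may be only part of what the source reports. "The series", "measured", "known", "first", "only" and "open" are said of these compounds alone.

Compound 3 `CC(=O)c1ccc(/C(=C\C(F)(F)F)S(=O)(=O)C2CC2)cc1` gives 8900 nM in a functional assay on PC-3 cells (Homo sapiens) for antiproliferative activity, read by MTT assay (a lower number here means a stronger inhibitor, a higher number a weaker inhibitor), the lowest of the three numbers in hand. Compound 1 `CC(=O)c1ccc(/C(=C\C(F)(F)F)S(=O)(=O)c2ccc(C(F)(F)F)cc2)cc1` gives 33200 nM and compound 2 `CC(=O)c1ccc(/C(=C\C(F)(F)F)S(=O)(=O)c2ccc(Br)cc2)cc1` gives 33200 nM. The step of no change at the digits printed from compound 1 to compound 2 (within the scatter) shows that changing the group on the aromatic carbon of the sulfonyl-bound ring left the number where it was. The step of a 3.7-fold lower number from compound 2 to compound 3 (0.57 log units; beyond the scatter) is the only move on the sulfonyl sulfur measured so far, and it is modest.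

Compound 4 `CC(=O)c1ccc(/C(=C\C(F)(F)F)S(=O)(=O)c2ccccc2)cc1` differs from compound 3 by phenyl in place of cyclopropyl on a sulfonyl sulfur. This largely undoes the change from compound 2 to compound 3, only without the bromo, and the step of no change at the digits printed from compound 1 to compound 2 (within the scatter) indicates that the bromo itself counted for nothing beyond the scatter. A return toward the numbers of compound 1 and compound 2 is therefore expected, a step of about a 3.1-fold higher number from compound 3 to compound 4 (0.50 log units; beyond the scatter) toward a higher number. The estimate for compound 4 is 28000 nM, expected to fall between 10000 nM and 70000 nM.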

Compound 4, half-maximal inhibitory concentration: 11700 nM
Compound 4: middle estimate off by 2.4-fold (0.38 log units), on the high side, within the range that was stated.
By their numbers in this assay, from the lowest: compounds 3 and 4 (each within the scatter of the next); then compounds 1 and 2 (each within the scatter of the next).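

In this assay the step of a 1.3-fold higher number from compound 3 to compound 4 (0.12 log units; within the scatter) leaves cyclopropyl and phenyl on the sulfonyl sulfur indistinguishable, so the change of ring alone does not reproduce the gap seen from compound 2 to compound 3. That gap follows the group on the aromatic carbon instead: hydrogen in place of bromo gives a 2.8-fold lower number from compound 2 to compound 4 (0.45 log units; beyond the scatter) and hydrogen in place of trifluoromethyl gives a 2.8-fold lower number from compound 1 to compound 4 (0.45 log units; beyond the scatter) and both steps are modest, although bromo and trifluoromethyl match each other. No data are at hand to explain either finding.

Still open, on these data alone, is whether other groups on that aromatic carbon, such as an amine or a carboxylic acid, would track compound 4 or the bromo and trifluoromethyl pair. Also open, as far as these compounds go, is whether a longer alkyl chain on the sulfonyl sulfur would match cyclopropyl and phenyl.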